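The source may report more compounds than this note shows. Statements on the series, on what has been measured and on what is new or still open speak of the compounds shown alone.

Measured so far in a physicochemical assay for lipophilicity, at pH 7.4; on this read-out higher numbers stand for higher lipophilicity and lower numbers for lower lipophilicity:
- compound 1 `Cc1cc(C(=O)NCc2ccncc2)nn1Cc1cc(Cl)ccc1OCc1ccccc1` gives > 3.7 as a limit
- compound 2 `Cc1cc(NC(=O)CC2CCCCC2)nn1Cc1cc(Cl)ccc1OCc1ccccc1` gives 3.2 as a number
- compound 3 `Cc1cc(NC(=O)OC(C)(C)C)nn1Cc1cc(Cl)ccc1OCc1ccccc1` gives > 3.7 as a limit

Compound 3 stands at the limit of > 3.7 in this assay, at which 2 of the 3 values shown sit, and so carries a limit and no number. Compound 4 `Cc1cc(NC(=O)O[C@H]2CCOC2)nn1Cc1cc(Cl)ccc1OCc1ccccc1` differs from it in one place, with oxolan-3-yl in place of tert-butyl on an oxygen next to a carbonyl group and the rest unchanged.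

The nearest measured change is a number at least 0.50 log units higher from compound 2 to compound 3 (beyond the scatter) when tert-butoxy comes in place of cyclohexylmethyl on a carbonyl carbon. By contrast, a step that the two limits leave unreadable from compound 1 to compound 3 gives no size to work with. Among the compounds with values here, a change on this carbonyl can therefore carry the number beyond the scatter, although no measured compound holds oxolan-3-yl. A modest move to a lower number is expected on that single step from compound 2 to compound 3, and the estimate is a number at least 0.50 log units lower from compound 3 to compound 4 (beyond the scatter) as the expected change. In this assay the estimated value for compound 4 is 3.2 within an expected range from 2.7 to 3.7.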

Compound 4, distribution coefficient: 2.7
Compound 4: the middle estimate sits 0.50 log units above what was measured; measured number inside the range.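

In this assay, oxolan-3-yl in place of tert-butyl on an oxygen next to a carbonyl group gives a number at least 1.00 log units lower from compound 3 to compound 4 (beyond the scatter), the first change shown within this oxygen-linked group. With (oxolan-3-yl)oxy in place of cyclohexylmethyl on a carbonyl carbon, the result is a number 0.50 log units lower from compound 2 to compound 4 (beyond the scatter), the opposite direction to the step with tert-butoxy, while (((oxolan-3-yl)oxy)carbonyl)amino in place of ((pyridin-4-yl)methyl)carbamoyl on an aromatic carbon gives a number at least 1.00 log units lower from compound 1 to compound 4 (beyond the scatter). Compound 3 carries only a limit, so the step from it has a floor and no full size: the limit of > 3.7 in this assay, at which 2 of the 4 values shown sit.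

The compounds shown leave open whether the ring oxygen of oxolan-3-yl or the ring alone carries this step, a question that a cyclopentyl group on the same oxygen would separate. They also leave open what the opposite stereocentre, or an amine on the ring, would do.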